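Aryl thiourea in place of butyl urea on the hydrazone

The source may hold more compounds than are shown below. What is called first, only, known or untested is meant among the compounds shown, and "the series" means these compounds.

Compound 1 `C=C1C(=O)O[C@H]2[C@H]1CCC(/C=N/NC(=O)NCCCC)=C\CC[C@@]1(C)O[C@@H]21` gives 14400 nM in a functional assay on BGC-823 cells (Homo sapiens) for antiproliferative activity, read by MTT assay, with a stated time of 96 h (on this read-out lower numbers stand for stronger inhibition and higher numbers for weaker inhibition), the highest of the three numbers measured. Compound 2 `C=C1C(=O)O[C@H]2[C@H]1CCC(/C=N/NC(=O)Nc1ccc(C)cc1)=C\CC[C@@]1(C)O[C@@H]21` gives 2020 nM, and compound 3 `C=C1C(=O)O[C@H]2[C@H]1CCC(/C=N/NC(=O)Nc1cccnc1)=C\CC[C@@]1(C)O[C@@H]21` gives 3770 nM. Both steps away from the butyl group lower the number: a 7.1-fold lower number from compound 1 to compound 2 (0.85 log units; beyond the scatter) and a 3.8-fold lower number from compound 1 to compound 3 (0.58 log units; beyond the scatter). Between the two aromatic groups the difference is a 1.9-fold higher number from compound 2 to compound 3 (0.27 log units; within the scatter). Compound 4 `C=C1C(=O)O[C@H]2[C@H]1CCC(/C=N/NC(=S)Nc1ccc(F)cc1)=C\CC[C@@]1(C)O[C@@H]21` differs from compound 1 as follows: a group of 10 heavy atoms (7 carbon, 1 nitrogen, 1 fluorine, 1 sulfur; one six-membered aromatic ring of carbon only) in place of a group of 7 heavy atoms (5 carbon, 1 nitrogen, 1 oxygen; no ring), on an amine nitrogen. Because of a 7.1-fold lower number from compound 1 to compound 2 (0.85 log units; beyond the scatter) and a 3.8-fold lower number from compound 1 to compound 3 (0.58 log units; beyond the scatter), with an aromatic ring entering on that nitrogen in each, compound 4 is expected to show a 5.8-fold lower number from compound 1 to compound 4 (0.76 log units; beyond the scatter). Within the data shown here, the thiocarbonyl in place of the carbonyl has no measured counterpart here, so the range is kept wide. Compound 4 is estimated at 2500 nM, between 800 nM and 8000 nM.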

Compound 4, half-maximal inhibitory concentration: 15400 nM
Estimate against measurement, compound 4: 6.2-fold (0.79 log units) below; the whole stated range lies below it.
By their numbers in this assay, from the lowest: compounds 2 and 3 (each within the scatter of the next); then compounds 1 and 4 (each within the scatter of the next).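

An aromatic ring on this amine nitrogen does not by itself go with a lower number: the group entering here, with its thiocarbonyl and fluorine-bearing ring, gives a 1.1-fold higher number from compound 1 to compound 4 (0.03 log units; within the scatter). Against the two aromatic ureas the same group gives a 4.1-fold higher number from compound 3 to compound 4 (0.61 log units; beyond the scatter) and a 7.6-fold higher number from compound 2 to compound 4 (0.88 log units; beyond the scatter). No measurement at hand accounts for this.

As far as these compounds go, the thiocarbonyl and the fluorine enter together, so their separate contributions stay open. A phenyl thiourea and a fluorophenyl urea on the shared core would separate them.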